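Benzyl for methyl on the core nitrogen: one step, transferred

The source may report more compounds than this note shows. Statements on the series, on what has been measured and on what is new or still open speak of the compounds shown alone.

Compound 2 `CN1CCN(c2ccc(NC(=N)c3cc4cn(C)nc4cn3)cc2)CC1` carries a methyl on an aromatic nitrogen of its core; in a functional assay on MDA-MB-231 cells (Homo sapiens) for cytotoxicity, read by MTT assay, with a stated time of 72 h (a higher number here means a weaker inhibitor, a lower number a stronger inhibitor), compound 2 gives 20500 nM. Compound 1 `COc1ccc(Cn2cc3cc(C(=N)Nc4ccc(N5CCN(C)CC5)cc4)ncc3n2)cc1` differs from it by 4-methoxyphenyl in place of hydrogen on a saturated chain carbon bound to an aromatic nitrogen and in this assay compound 1 gives 8000 nM, so that a 2.6-fold lower number from compound 2 to compound 1 (0.41 log units; beyond the scatter). Compound 3 `Cn1nc(-c2ccccc2)c2cc(C(=N)Nc3cccc(C(F)(F)F)c3)ncc21` is built on a differently substituted core; the difference between the cores of compound 2 and compound 3 is not broken down here. In this assay compound 3 gives 21400 nM, a number within the scatter of compound 2. Compound 4 `COc1ccc(Cn2nc(-c3ccccc3)c3cc(C(=N)Nc4cccc(C(F)(F)F)c4)ncc32)cc1` differs from compound 3 by 4-methoxyphenyl in place of hydrogen on a saturated chain carbon bound to an aromatic nitrogen, the same change at the same place. For the measured compounds named here, the step from compound 3 to compound 4 is expected to be about as large as the earlier one, a 2.4-fold lower number from compound 3 to compound 4 (0.38 log units; beyond the scatter), because a 2.6-fold lower number from compound 2 to compound 1 (0.41 log units; beyond the scatter) is the only measured instance of this change. Compound 4 is therefore estimated at 9000 nM, with a likely range from 4000 nM to 20000 nM.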

Compound 4, half-maximal inhibitory concentration: > 50000 nM
Compound 4: only a limit was reported; the forecaster's own chance of this, stated with the estimate: 5%; middle value at least 5.5-fold (0.74 log units) from the limit.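

In this assay compound 4 gives > 50000 nM, which is a limit of the assay and not a number. On the core of compound 3, methyl to 4-methoxybenzyl gives an at least 2.3-fold higher number from compound 3 to compound 4 (0.36 log units; beyond the scatter), so the step seen on the core of compound 2 does not carry over: the same change on two cores in this assay, a 2.6-fold lower number (0.41 log units; beyond the scatter) from compound 2 to compound 1 and an at least 2.3-fold higher number (0.36 log units; beyond the scatter) from compound 3 to compound 4, at least 5.9-fold (0.77 log units) apart, beyond the scatter of two such steps With one pair per core, this shows that the outcome of the change depends on its setting in these compounds, but not how large the step from compound 3 really is: the limit of > 50000 nM in this assay, at which 1 of the 4 values shown sits.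

From the compounds shown here alone, compound 2 and compound 3 differ in more than one place, so it stays open which of those places sets the direction of the step. Also open, going by these compounds, is whether an unsubstituted benzyl or a longer chain ending in an amine would behave alike on both cores.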